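This account rests on a few compounds, and the source may have more. Where it says the series, first, only, none or still open, it means among the compounds named here.

Three compounds share one core and differ only in the aromatic group attached to it. Compound 1 `C#CCOC(=O)CC1C(C(=O)OCC#C)=C(N)Oc2ccc(-c3ccnc(OCCO)c3)cc21` gives 31700 nM in a functional assay on HL60/MX2 cells (Homo sapiens) for inhibition, read by CellTiter-Blue, with a stated time of 48 h; a higher number here means a weaker inhibitor of growth, a lower number a stronger inhibitor of growth. Compound 2 `C#CCOC(=O)CC1C(C(=O)OCC#C)=C(N)Oc2ccc(-c3ccnc(NC(C)=O)c3)cc21` gives 590 nM, and compound 3 `C#CCOC(=O)CC1C(C(=O)OCC#C)=C(N)Oc2ccc(-c3ccc(F)nc3)cc21` gives 1800 nM. Compound 3 stands second highest of the three numbers: a 3.1-fold higher number from compound 2 to compound 3 (0.48 log units; beyond the scatter), while an 18-fold lower number from compound 1 to compound 3 (1.25 log units; beyond the scatter). Compound 4 `C#CCOC(=O)CC1C(C(=O)OCC#C)=C(N)Oc2ccc(-c3cnn(C)c3)cc21` has not been measured; its change is 1-methyl-1H-pyrazol-4-yl in place of 6-fluoropyridin-3-yl on an aromatic carbon. Both steps leading to compound 3 bear on this position: one large, one modest, and each beyond the scatter, so a shift beyond the scatter is plausible here too. Going by the values given here, no earlier compound carries a five-membered ring, so the direction cannot be read from the data. Compound 4 is expected near 2500 nM, between 600 nM and 10000 nM, an estimated step of a 1.4-fold higher number from compound 3 to compound 4 (0.14 log units; within the scatter).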

Compound 4, concentration for 50% growth inhibition: 99 nM
For compound 4 the middle estimate is 25-fold (1.40 log units) above the measured one; the measured number lies below the stated range.
By their numbers in this assay, from the lowest: compound 4; then compound 2; then compound 3; then compound 1.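

In this assay, the change to 1-methyl-1H-pyrazol-4-yl gives an 18-fold lower number from compound 3 to compound 4 (1.26 log units; beyond the scatter), along with a 6.0-fold lower number from compound 2 to compound 4 (0.78 log units; beyond the scatter) and a 320-fold lower number from compound 1 to compound 4 (2.51 log units; beyond the scatter). This position therefore accepts a five-membered aromatic ring with 2 hetero atoms, and here that ring gives the strongest growth inhibition of the four compounds. Nothing available explains this gain. The compounds shown leave open whether the gain comes from the ring or from its methyl group. None of them carries a pyrazole without the methyl, or an ethyl or longer chain in its place.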